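Swapping a Nitrile for an Ester on Two Cores

The source may report more compounds than this note shows. Statements on the series, on what has been measured and on what is new or still open speak of the compounds shown alone.

Compound 1 `Cc1ccc2nc(C)n(-n3c(N)c(C#N)c(-c4ccccc4)c(C#N)c3=O)c(=O)c2c1` and compound 2 `CCOC(=O)c1c(-c2ccccc2)c(C#N)c(=O)n(-n2c(C)nc3ccc(C)cc3c2=O)c1N` share one core, while compound 3 `Cc1ccc2nc(C)n(NC(=O)c3sc(N)c(C#N)c3N)c(=O)c2c1` and compound 4 `CCOC(=O)c1c(N)sc(C(=O)Nn2c(C)nc3ccc(C)cc3c2=O)c1N` share another; the difference between the two cores is not broken down here. All four belong to a functional assay on HepG2 cells (Homo sapiens) for cytotoxicity, read by MTT assay, with a stated time of 3 days; on this read-out higher numbers stand for weaker inhibition and lower numbers for stronger inhibition. In this assay compound 1 gives 10000 nM, compound 2 gives 52000 nM and compound 3 gives 15000 nM. The step of a 5.2-fold higher number from compound 1 to compound 2 (0.72 log units; beyond the scatter) arises from the change (ethoxycarbonyl in place of cyano on an aromatic carbon). Compound 4 carries the same kind of change on the other core, (ethoxycarbonyl in place of cyano on an aromatic carbon), but the surroundings are not the same: in compound 1 the place is a six-membered aromatic ring with 1 nitrogen, ortho to a phenyl group and ortho to an amino group, whereas in compound 3 it is a five-membered aromatic ring with 1 sulfur, next to two ring atoms that each bear an amino group. Compound 3 and compound 1 lie within the scatter of each other, and compound 2 stands beyond the scatter from both. Within the data shown here, for compound 4 the step is expected to be a 3.0-fold higher number from compound 3 to compound 4 (0.48 log units; beyond the scatter) because a 5.2-fold higher number from compound 1 to compound 2 (0.72 log units; beyond the scatter) is the only precedent and points toward a higher number, though the different surroundings leave the size uncertain. Compound 4 is therefore estimated at 45000 nM, with a likely range from 15000 nM to 150000 nM.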

Compound 4, half-maximal inhibitory concentration: 22000 nM
The estimate for compound 4 lay 2.0-fold (0.31 log units) above the measured number; the range from low to high includes it.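

In this assay the exchange of cyano for ethoxycarbonyl on the core of compound 3 gives a 1.5-fold higher number from compound 3 to compound 4 (0.17 log units; within the scatter) and so leaves the two compounds indistinguishable on this read-out. The same change therefore does not carry over in size from one core to the other, and the gap between the two steps is larger than repeated measurement alone would be expected to produce: the same change on two cores in this assay, a 5.2-fold higher number (0.72 log units; beyond the scatter) from compound 1 to compound 2 and a 1.5-fold higher number (0.17 log units; within the scatter) from compound 3 to compound 4, 3.5-fold (0.55 log units) apart, beyond the scatter of two such steps. Among these compounds, with a single pair on each core, this shows only that the step seen on the core of compound 1 cannot be transferred to the core of compound 3 in this series; it does not show that the change acts in the same direction on both cores, nor which difference between the cores lies behind the gap, and it gives no general rule for other cores.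

The compounds shown leave open whether a carboxylic acid, a primary carboxamide or a methoxycarbonyl group at the same place would behave on each core as the ethoxycarbonyl group does. Among the compounds shown here, they also leave open whether the amino groups on the ring carrying the change have any bearing on the size of the step, as no pair here varies them.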